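A few compounds are considered here, and "the series" means these few. Any claim that something is new, unique, unknown or untested is made for them only; others in the source may bear on it.

In an ADME assay on MT4 cells (Homo sapiens) for cytotoxicity, read by MTT assay, with a stated time of 5 days (a higher number here means that more compound is tolerated, a lower number that less compound is tolerated), compound 1 `O=C1N(Cc2cccc(Cl)c2)c2cccn2S(=O)(=O)N1Cc1ccccc1` gives 196000 nM, and compound 2 `O=C1N(Cc2ccccc2)c2cccn2S(=O)(=O)N1Cc1ccccc1` gives 196000 nM. Compound 3 `N#Cc1ccccc1CN1C(=O)N(Cc2ccccc2)S(=O)(=O)n2cccc21` gives > 318000 nM, which is a limit of this assay and not a number. Compound 3 thus sits at the limit of > 318000 nM in this assay, at which 1 of the 3 values shown sits, the highest point the data reach. Compound 4 `O=C1N(Cc2ccc(F)cc2)c2cccn2S(=O)(=O)N1Cc1ccccc1` differs from compound 3 by 4-fluorophenyl in place of 2-cyanophenyl on a saturated chain carbon bound to an amide-type nitrogen in a ring. The measured steps that bear on this are an at least 1.6-fold higher number from compound 1 to compound 3 (0.21 log units; that floor lies within the scatter) and an at least 1.6-fold higher number from compound 2 to compound 3 (0.21 log units; that floor lies within the scatter), both ending at the limit, together with no change at the digits printed from compound 1 to compound 2 (within the scatter). Since compound 4 carries a fluorophenyl rather than the cyanophenyl of compound 3, it is expected to return toward the region of compounds 1 and 2. Compound 4 is therefore expected to show an at least 1.3-fold lower number from compound 3 to compound 4 (0.12 log units; that floor lies within the scatter), nothing beyond the scatter. Compound 4 is estimated at 240000 nM, between 120000 nM and 400000 nM.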

Compound 4, half-maximal cytotoxic concentration: 150000 nM
The estimate for compound 4 lay 1.6-fold (0.20 log units) above the measured number; low and high end bracket the measured number.
By their numbers in this assay, from the lowest: compounds 4, 1 and 2 (each within the scatter of the next). At a limit, above all of these: compound 3.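

In this assay, the change from 2-cyanobenzyl to 4-fluorobenzyl gives the only step shown that lies beyond the scatter, with an at least 2.1-fold lower number from compound 3 to compound 4 (0.32 log units; beyond the scatter). Fluoro in place of hydrogen leaves the number within the scatter, with a 1.3-fold lower number from compound 2 to compound 4 (0.12 log units; within the scatter), and the swap from 3-chlorophenyl does the same, with a 1.3-fold lower number from compound 1 to compound 4 (0.12 log units; within the scatter). Compound 3 alone stands at a limit of the assay: the limit of > 318000 nM in this assay, at which 1 of the 4 values shown sits.

As far as these compounds go, whether an aminophenyl or a carboxyphenyl on this saturated chain carbon would behave like 2-cyanophenyl or like 4-fluorophenyl stays open. So does the true value of compound 3.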